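Ethoxy to methyl: compound 3 to compound 4

A few compounds are considered here, and "the series" means these few. Any claim that something is new, unique, unknown or untested is made for them only; others in the source may bear on it.

In a functional assay on PANC-1 cells (Homo sapiens) for antiproliferative activity, read by MTT assay, with a stated time of 48 h (on this read-out higher numbers stand for weaker inhibition and lower numbers for stronger inhibition), compound 1 (`COc1ccc(-c2c(Nc3ccc(C)cc3)c3ccccc3oc2=O)cc1`) gives 66100 nM as its value, and compound 2 (`COc1ccc(-c2c(Nc3ccc(C)c(O)c3)c3ccc(OC)cc3oc2=O)cc1`) gives 31300 nM as its value. Compound 3 (`CCOc1ccc(Nc2c(-c3ccc(OC)cc3)c(=O)oc3cc(OC)ccc23)cc1`) gives 36100 nM and sits within the scatter of both compound 2 and compound 1. Compound 4 (`COc1ccc(-c2c(Nc3ccc(C)cc3)c3ccc(OC)cc3oc2=O)cc1`) has methyl in place of ethoxy on an aromatic carbon, para to a large group (methyl in place of ethoxy on an aromatic carbon). Among the measured compounds shown here, the one measured step bearing on this change puts 4-ethoxyphenyl in place of 3-hydroxy-4-methylphenyl, and it stays small (a 1.2-fold higher number from compound 2 to compound 3 (0.06 log units; within the scatter)). No step beyond the scatter is therefore expected in this assay for this change. The estimate implies an expected step inside the scatter (a 1.1-fold higher number from compound 3 to compound 4 (0.02 log units; within the scatter)). For compound 4 the estimated value is 38000 nM (expected range 21000 nM to 68000 nM).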

Compound 4, half-maximal inhibitory concentration: 76500 nM
Estimate against measurement, compound 4: 2.0-fold (0.30 log units) below; measured number outside the range, above it.
By their numbers in this assay, from the lowest: compounds 2, 3, 1 and 4 (each within the scatter of the next, the first and the last beyond it).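

In this assay this position on the ring proves sensitive to the group it carries: methyl in place of ethoxy gives a 2.1-fold higher number from compound 3 to compound 4 (0.33 log units; beyond the scatter), whereas the earlier step at this nitrogen substituent stayed within the scatter. Hydrogen in place of hydroxy on the same ring also registers, with a 2.4-fold higher number from compound 2 to compound 4 (0.39 log units; beyond the scatter), while methoxy in place of hydrogen on the core gives only a 1.2-fold higher number from compound 1 to compound 4 (0.06 log units; within the scatter). No measurement shown accounts for these steps. Going by these compounds, whether a longer alkoxy chain such as propoxy, or an amine, at this position would match ethoxy or methyl remains open. Also open, on these data alone, is whether the ethoxy-to-methyl step holds on the core of compound 1.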